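The compounds below may be only part of what the source reports. "The series", "measured", "known", "first", "only" and "open" are said of these compounds alone.

Measured compounds:
compound 1, `CC(=O)N1N=C(c2ccc(OCc3cn(Cc4ccc([N+](=O)[O-])cc4)nn3)cc2)CC1c1ccccc1`, 18%
compound 2, `COc1ccc(C2CC(c3ccc(OCc4cn(Cc5ccc([N+](=O)[O-])cc5)nn4)cc3)=NN2C(C)=O)cc1`, 4%
compound 3, `COc1cc(C2CC(c3ccccc3)=NN2C(C)=O)ccc1OCc1cn(Cc2ccc([N+](=O)[O-])cc2)nn1`, 7%

In a functional assay on COLO 205 cells (Homo sapiens) for inhibition, read by sulforhodamine B assay, tested at 10 uM (on this read-out higher numbers stand for more inhibition of growth at the one concentration tested and lower numbers for less inhibition of growth), compound 2 stands at the low end of the three numbers; compound 3 sits within the scatter of it, while compound 1 lies beyond the scatter above it. Compound 4 `COc1ccc(C2CC(c3ccc(OCc4cn(Cc5ccc([N+](=O)[O-])cc5)nn4)cc3)=NN2C(C)=O)cc1OC` differs from compound 2 by methoxy in place of hydrogen on an aromatic carbon. One measured step is of the same kind: a number 14 percentage points lower from compound 1 to compound 2 (beyond the scatter). That step lowered the number, but compound 2 already stands close to the floor of this read-out, so little room remains in that direction. The step is therefore expected to be a number 1 percentage points lower from compound 2 to compound 4 (within the scatter), nothing beyond the scatter. Compound 4 is estimated at 3%, expected to fall between -8% and 14%.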

Compound 4, percent growth inhibition at one concentration: 9%
Compound 4: the middle estimate sits 6 percentage points below what was measured, and the stated range covers the measured number.
By their numbers in this assay, from the lowest: compounds 2, 3, 4 and 1 (each within the scatter of the next, the first and the last beyond it).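

In this assay, a methoxy placed ortho to a methoxy group, turning 4-methoxyphenyl into 3,4-dimethoxyphenyl, gives a number 5 percentage points higher from compound 2 to compound 4 (within the scatter), so this position shows no effect that can be told from the scatter. Set against the unsubstituted phenyl, 3,4-dimethoxyphenyl gives a number 9 percentage points lower from compound 1 to compound 4 (within the scatter), whereas the single methoxy gave a number 14 percentage points lower from compound 1 to compound 2 (beyond the scatter); the drop beyond the scatter is therefore not seen with the second methoxy in place. Nothing available explains this result. As far as these compounds go, whether a hydroxyl or an amine at this position would raise the number remains open, as does whether any change on this ring can lift growth inhibition well above that of compound 1.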